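Bromoethenylcarbonyl anilide series: change of the aryl ether

A few compounds are considered here, and "the series" means these few. Any claim that something is new, unique, unknown or untested is made for them only; others in the source may bear on it.

Among the compounds with values here, compound 2 `C=C(Br)C(=O)Nc1cccc(-c2cn3nc(-c4ccc(OCC)cc4)sc3n2)c1` gives 790 nM in a functional assay on L1210 cells (Mus musculus) for inhibition, read by cell counting, with a stated time of 2 days (on this read-out higher numbers stand for weaker inhibition and lower numbers for stronger inhibition), the lowest of the two numbers so far; compound 1 `CCOc1ccc(-c2nn3cc(-c4cccc(N)c4)nc3s2)cc1` gives 155000 nM. Within the data shown here, the only measured step, a 200-fold lower number from compound 1 to compound 2 (2.29 log units; beyond the scatter), concerns the (1-bromoethenyl)carbonyl group on the nitrogen on the aromatic ring and leaves the aryl ether untouched, so it does not bear on the present change. Compound 3 `C=C(Br)C(=O)Nc1cccc(-c2cn3nc(-c4ccc(OC)c(OC)c4)sc3n2)c1` differs from compound 2 by 3,4-dimethoxyphenyl in place of 4-ethoxyphenyl on an aromatic carbon. Among the measured compounds shown here, no measured pair varies this aryl group, so the direction of the step is not indicated by the data; the shared core and the (1-bromoethenyl)carbonyl group of compound 2 are retained, and the expected step is a 1.3-fold higher number from compound 2 to compound 3 (0.10 log units; within the scatter), not clearly beyond the scatter. Compound 3 is therefore estimated at 1000 nM in this assay, with a range from 300 nM to 3500 nM.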

Compound 3, half-maximal inhibitory concentration: 42 nM
Compound 3: the middle estimate sits 24-fold (1.38 log units) above what was measured, outside the stated range (below it).
By their numbers in this assay, from the lowest: compound 3; then compound 2; then compound 1.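

In this assay the aryl group on the aromatic carbon next to the ring sulfur is not a silent position: 3,4-dimethoxyphenyl in place of 4-ethoxyphenyl gives a 19-fold lower number from compound 2 to compound 3 (1.27 log units; beyond the scatter) with the (1-bromoethenyl)carbonyl group held fixed. Within the data shown here, the earlier step changed only the group on the nitrogen, so this is the first sign that the number also responds to the aryl ether. No measurement at hand accounts for the size of this step.

The change alters two things at once, the ether chain and the number of oxygens on the ring, and the compounds shown do not separate them; 4-methoxyphenyl, 3-methoxyphenyl or 3,4-diethoxyphenyl at this position would. Also open, on these data alone, is whether the step carries over to the free amine of compound 1, or to an unsubstituted phenyl.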